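Swapping chloro for bromo on compound 3

A few compounds are considered here, and "the series" means these few. Any claim that something is new, unique, unknown or untested is made for them only; others in the source may bear on it.

compound 1 `NC(=O)c1cc(Cl)ccc1NC(=O)/C=C/c1ccccc1Br`: 10000 nM
compound 2 `Cc1cccc(/C=C/C(=O)Nc2ccc(Cl)cc2C(N)=O)c1`: > 10000 nM (a limit)
compound 3 `NC(=O)c1cc(Br)ccc1NC(=O)/C=C/c1cccc(Cl)c1`: > 10000 nM (a limit)

All three values come from a functional assay on K562 cells (Homo sapiens) for inhibition, read by trypan blue exclusion, with a stated time of 48 h; a higher number here means a weaker inhibitor, a lower number a stronger inhibitor. For compound 3, the entry > 10000 nM is a limit and not a number. Compound 4 `NC(=O)c1cc(Br)ccc1NC(=O)/C=C/c1cccc(Br)c1` carries bromo in place of chloro on an aromatic carbon, (bromo in place of chloro on an aromatic carbon). Among the compounds with values here, the only measured step, a number no lower from compound 1 to compound 2 (the limit leaves the size open), changes a different group and has no readable size, so it cannot size this swap. The series offers the limit of > 10000 nM in this assay, at which 2 of the 3 values shown sit, as its main reference point. No step beyond the usual scatter is therefore expected, and the estimated step is a step that the limit leaves unreadable from compound 3 to compound 4. Compound 4 is expected near 15000 nM, within an estimated range of 7000 nM to 30000 nM.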

Compound 4, half-maximal inhibitory concentration: > 10000 nM
Compound 4: only a limit was reported (the forecaster's own chance of this, stated with the estimate: 70%); the middle value lies beyond the limit too.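

In this assay, within the data shown here, compound 3 and compound 4 are both reported only as limits, and no step between them can be read. Still open, as far as these compounds go, is how strongly either compound inhibits, and whether bromo in place of chloro changes that at all.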